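Moving a Hydroxyl Group on a Pyridine Core

A few compounds are considered here, and "the series" means these few. Any claim that something is new, unique, unknown or untested is made for them only; others in the source may bear on it.

Of the compounds shown here, three that share one core have been tested in a functional assay on HeLa cells (Homo sapiens) for cytotoxicity, read by CCK-8 assay; on this read-out higher numbers stand for weaker inhibition and lower numbers for stronger inhibition. Compound 1 `Oc1ccc(-c2cc(-c3ccsc3)cc(-c3ccc(O)cc3)n2)cc1` gives 4370 nM in this assay. Compound 2 `Oc1ccc(-c2cc(-c3ccccn3)cc(-c3ccc(O)cc3)n2)cc1` reaches only the limit of > 50000 nM, so no number is known for it. The change an at least 11-fold higher number from compound 1 to compound 2 (1.05 log units; beyond the scatter) is thus a large loss. Compound 3 `Oc1ccc(-c2cc(-c3cccnc3)cc(-c3ccccc3O)n2)cc1` also stops at the limit of > 50000 nM in this assay. Compound 3 therefore stands at the limit of > 50000 nM in this assay, at which 2 of the 3 values shown sit, and its true value could lie anywhere beyond it.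

Compound 4 `Oc1ccc(-c2cc(-c3cccnc3)cc(-c3ccc(O)cc3)n2)cc1` is not yet measured. It differs from compound 3 in one place: 4-hydroxyphenyl in place of 2-hydroxyphenyl on an aromatic carbon. Among the compounds with values here, no measured step involves this particular swap, so its size cannot be read from the steps at hand. Within the data shown here, the only measured step, an at least 11-fold higher number from compound 1 to compound 2 (1.05 log units; beyond the scatter), concerns a different group, so it bears on compound 4 only in showing how far a single change can move the numbers. Because compound 3 already sits at the limit of > 50000 nM, a weak result for compound 4 is expected, with a fair chance of another limit. Compound 4 is estimated at 30000 nM, in the range 8000 nM to 100000 nM. The expected step is an at least 1.6-fold lower number from compound 3 to compound 4 (0.22 log units; that floor lies within the scatter), stated loosely because compound 3 has only a limit.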

Compound 4, half-maximal inhibitory concentration: 600 nM
Compound 4: middle estimate off by 50-fold (1.70 log units), on the high side, outside the stated range (below it).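

Swapping the 2-hydroxyphenyl group next to the ring nitrogen for a 4-hydroxyphenyl group gives an at least 83-fold lower number from compound 3 to compound 4 (1.92 log units; beyond the scatter) in this assay, so this position clearly distinguishes the two groups even though they contain the same atoms. The other substituent on the shared core also matters: pyridin-3-yl in place of pyridin-2-yl gives an at least 83-fold lower number from compound 2 to compound 4 (1.92 log units; beyond the scatter), and pyridin-3-yl in place of thiophen-3-yl gives a 7.3-fold lower number from compound 1 to compound 4 (0.86 log units; beyond the scatter), which makes compound 4 the most potent of the four compounds and shows that the place of the nitrogen in the pyridine ring counts. Compound 2 and compound 3 each stop at a limit rather than a true number, so the two steps that start from them give only the smallest possible size of the change: the limit of > 50000 nM in this assay, at which 2 of the 4 values shown sit.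

From the compounds shown here alone, whether a 3-hydroxyphenyl group would behave more like the 4-hydroxyphenyl or the 2-hydroxyphenyl group remains open, as does the effect of replacing the hydroxyl with a methoxy group, an amine or a carboxylic acid. Going by these compounds, it is also open how a 2-hydroxyphenyl group would act alongside thiophen-3-yl or pyridin-2-yl on the same core.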